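A Chloro Swapped for Hydroxy Among Weak Inhibitors

The source may hold more compounds than are shown below. What is called first, only, known or untested is meant among the compounds shown, and "the series" means these compounds.

Within the data shown here, in a functional assay on MT4 cells (Homo sapiens) for inhibition (on this read-out higher numbers stand for weaker inhibition and lower numbers for stronger inhibition), compound 3 `C=C1[C@H](n2cnc3c(Cl)nc(N)nc32)O[C@H](CO)[C@H]1O` gives 176000 nM, the only true number in this small set. Compound 1 `C=C1[C@@H](O)[C@H](n2cnc3c(O)nc(N)nc32)O[C@@H]1CO` is reported only as a limit, > 200000 nM. Compound 2 `C=C1[C@@H](O)[C@H](n2cnc3c(N(C)C)nc(N)nc32)O[C@@H]1CO` is likewise reported only as a limit, > 500000 nM.

The next compound, compound 4 `C=C1[C@H](n2cnc3c(O)nc(N)nc32)O[C@H](CO)[C@H]1O`, places hydroxy in place of chloro on an aromatic carbon.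

Among the measured compounds shown here, the one measured step, which puts dimethylamino in place of hydroxy, is a step that the two limits leave unreadable from compound 1 to compound 2, so it offers no size to carry over. Compound 1 also carries hydroxy and stands only at its limit of > 200000 nM, which gives no reason to expect strong inhibition from this group. The expected change is a 1.1-fold higher number from compound 3 to compound 4 (0.06 log units; within the scatter), a shift that is not expected to exceed the usual scatter, although a reading that returns only a limit is quite possible. Compound 4 is estimated at 200000 nM, with an expected range of 40000 nM to 500000 nM.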

Compound 4, half-maximal inhibitory concentration: 150000 nM
Compound 4: the middle estimate sits 1.3-fold (0.12 log units) above what was measured; low and high end bracket the measured number.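

Hydroxy in place of chloro on this aromatic carbon gives a 1.2-fold lower number from compound 3 to compound 4 (0.07 log units; within the scatter) in this assay, the first change at this position with a readable size, as the earlier step to dimethylamino cannot be read. Chloro and hydroxy therefore cannot be told apart on this read-out, although hydroxy brings a hydrogen-bond donor and a hydrogen-bond acceptor that chloro does not. No measurement shown here bears on a reason for this result.

As far as these compounds go, what stays open is whether another group on this aromatic carbon, such as methoxy or a thiol, would move the number beyond the scatter on the core of compound 3. Dimethylamino also remains without a readable comparison, as it appears only on the core of compound 2 and not on the core of compound 3.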